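Swapping methyl for nitro on a weak growth inhibitor

The compounds below may be only part of what the source reports. "The series", "measured", "known", "first", "only" and "open" are said of these compounds alone.

Compound 1 `CC1=C(C(=O)Nc2ccccc2)C(c2cn(-c3ccccc3)nc2-c2ccccc2)NC(=O)N1` gives 80600 nM in a functional assay on MCF7 cells (Homo sapiens) for inhibition, read by sulforhodamine B assay, with a stated time of 24 h; a higher number here means a weaker inhibitor of growth, a lower number a stronger inhibitor of growth.
Compound 2 `CC1=C(C(=O)Nc2ccc(C)cc2)C(c2cn(-c3ccccc3)nc2-c2ccccc2)NC(=S)N1` gives 56100 nM in this assay.
Compound 3 `CC1=C(C(=O)Nc2ccccc2Cl)C(c2cn(-c3ccccc3)nc2-c2ccccc2)NC(=O)N1` gives 66600 nM in this assay.

Compound 2 sits at the lowest of the three numbers, yet its gaps to compound 3 and to compound 1 are within the scatter, so no ranking follows. For the measured compounds named here, the single one-point step measured so far, a 1.2-fold lower number from compound 1 to compound 3 (0.08 log units; within the scatter), also stayed within the scatter. Compound 4 `CC1=C(C(=O)Nc2ccc([N+](=O)[O-])cc2)C(c2cn(-c3ccccc3)nc2-c2ccccc2)NC(=S)N1` differs from compound 2 by nitro in place of methyl on an aromatic carbon. Going by the values given here, no measured step concerns this exchange; the one measured step, though on the same ring, involved a different group. The step expected for compound 4 is a 1.1-fold lower number from compound 2 to compound 4 (0.05 log units; within the scatter), nothing beyond the scatter. Compound 4 is estimated at 50000 nM, expected between 20000 nM and 130000 nM.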

Compound 4, concentration for 50% growth inhibition: 41400 nM
The estimate for compound 4 lay 1.2-fold (0.08 log units) above the measured number, within the range that was stated.
By their numbers in this assay, from the lowest: compounds 4, 2, 3 and 1 (each within the scatter of the next).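

Replacing 4-methylphenyl with 4-nitrophenyl gives a 1.4-fold lower number from compound 2 to compound 4 (0.13 log units; within the scatter) in this assay. At this place, para to a large group, a nitro group with its three heavy atoms and two hydrogen-bond acceptors can therefore stand in for a methyl group with no change beyond the scatter. No evidence here speaks to why the number stays within the scatter.

As far as these compounds go, whether an amine or a carboxylic acid at this place would give a step beyond the scatter remains open. So does how the same exchange would read on the core of compound 1.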